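Inverting one ring stereocentre at the stability limit

The compounds below may be only part of what the source reports. "The series", "measured", "known", "first", "only" and "open" are said of these compounds alone.

In an ADME assay for metabolic stability, read by HPLC, in simulated intestinal fluid, with a stated time of 12 h, at pH 6.8 (on this read-out lower numbers stand for a shorter-lived compound and higher numbers for a longer-lived compound), compound 1 (`O=C(O)[C@H](CO)NC(=O)[C@H]1C[C@H](O)CN1`) gives > 12 h, which is a limit of the assay. Compound 2 (`O=C(O)[C@@H](CO)NC(=O)[C@H]1C[C@@H](O)CN1`) gives > 12 h, also a limit, so it stands without a number of its own. The data show only (the limit of > 12 h in this assay, at which 2 of the 2 values shown sit).

Compound 3 (`O=C(O)[C@@H](CO)NC(=O)[C@H]1C[C@H](O)CN1`) departs from compound 2 in one respect: the two compounds have the same atoms and bonds and differ only in configuration as drawn: 1 of 3 stereo elements differ; a stereocentre at a saturated ring carbon is drawn R in compound 2 and S in compound 3.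

Going by the values given here, the one measured step that bears on this change is a step that the two limits leave unreadable from compound 1 to compound 2. It rests on (the fact that compounds 1 and 2 differ only in the configuration as drawn), and it offers no size to carry over. No step beyond the usual scatter is therefore expected in this assay, and no direction can be expected. The expected step is a step that the limit leaves unreadable from compound 2 to compound 3. Compound 3 is estimated at 14 h, with an expected range from 9 h to 24 h.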

Compound 3, half-life in the ADME assay: > 12 h
Compound 3: no number, only a limit; the forecaster's own chance of this, stated with the estimate: 85%; the middle value lies beyond the limit too.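

Going by these compounds alone, in the ADME assay compound 3 gives > 12 h, which is a limit of the assay, so no step from compound 1 or compound 2 to compound 3 can be read. In a physicochemical assay for metabolic stability, read by HPLC, with a stated time of 12 h, at pH 1.2 (on this read-out higher numbers stand for a longer-lived compound and lower numbers for a shorter-lived compound), compound 2 gives > 12 h, which is a limit of the assay. In the physicochemical assay compound 3 gives > 12 h, which is also a limit of the assay. The compounds shown leave open how long each lasts past that limit, and whether the configuration of either stereocentre matters.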